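From chloro to ethoxy on compound 1

This account rests on a few compounds, and the source may have more. Where it says the series, first, only, none or still open, it means among the compounds named here.

Values measured in a functional assay (mast cells) for inhibition, with Rattus norvegicus as the target (on this read-out lower numbers stand for an effect already at smaller amounts and higher numbers for an effect only at larger amounts of compound), are as follows.

- compound 1 `CC1CC/C(=N\Nc2cccc(Cl)c2)c2ncc(C(=O)O)c(=O)n21` gives 311000 nM
- compound 2 `CC1CC/C(=N\Nc2ccccc2O)c2ncc(C(=O)O)c(=O)n21` gives 208000 nM
- compound 3 `COc1ccc(N/N=C2\CCC(C)n3c2ncc(C(=O)O)c3=O)cc1` gives 128000 nM

Compound 1 stands at the upper end of these numbers, as shown by a 1.5-fold lower number from compound 1 to compound 2 (0.17 log units; within the scatter) and by a 2.4-fold lower number from compound 1 to compound 3 (0.39 log units; beyond the scatter). Compound 4 `CCOc1cccc(N/N=C2\CCC(C)n3c2ncc(C(=O)O)c3=O)c1` has ethoxy in place of chloro on an aromatic carbon. Neither measured step makes this exact change, but each replaces the same aryl group of compound 1. The closer guide is compound 3, which also brings an alkoxy group, so a modest step to a lower number in this assay is expected, possibly no larger than the scatter. The expected change is a 1.8-fold lower number from compound 1 to compound 4 (0.26 log units; within the scatter). Compound 4 is estimated at 170000 nM, with an expected range of 80000 nM to 360000 nM.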

Compound 4, half-maximal effective concentration: 4700 nM
For compound 4 the middle estimate is 36-fold (1.56 log units) above the measured one, outside the stated range (below it).
By their numbers in this assay, from the lowest: compound 4; then compounds 3, 2 and 1 (each within the scatter of the next, the first and the last beyond it).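

Placed meta to a large group, ethoxy in place of chloro gives a 66-fold lower number from compound 1 to compound 4 (1.82 log units; beyond the scatter) in this assay and so moves the number far more than any earlier change to the aryl group. An alkoxy group alone does not guarantee this outcome, since compound 3 with its 4-methoxyphenyl group stays at 128000 nM and compound 4 reaches a much lower number. No measurement shown here accounts for the large step. From the compounds shown here alone, whether propoxy, a longer ether chain or an amine at this same place would match ethoxy remains open.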